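Series notes: swapping the acid-bearing aryl group

A few compounds are considered here, and "the series" means these few. Any claim that something is new, unique, unknown or untested is made for them only; others in the source may bear on it.

Measured so far:
compound 1 `Cc1c(OC[C@@H](C)Oc2ccc(F)c(C(=O)O)c2)ccc(C(=O)CC(C)(C)C)c1O` gives 1210 nM in an assay for positive allosteric modulation of metabotropic glutamate receptor 3 (Rattus norvegicus); on this read-out higher numbers stand for an effect only at larger amounts of compound and lower numbers for an effect already at smaller amounts
compound 2 `Cc1c(OC[C@@H](C)COc2ccc(Cl)c(C(=O)O)c2)ccc(C(=O)CC(C)(C)C)c1O` gives 2200 nM in this assay

Among the compounds with values here, compound 2 stands at the highest of the two numbers so far, its nearest neighbour being compound 1, but the two values lie within the scatter of each other, so no order between them is claimed.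

Compound 3 `Cc1cc(OC[C@H](C)COc2ccc(C(=O)CC(C)(C)C)c(O)c2C)ccc1C(=O)O` is the next candidate. It differs from compound 2 by 4-carboxy-3-methylphenyl in place of 3-carboxy-4-chlorophenyl on an oxygen on a saturated carbon. Within the data shown here, no step between two measured compounds of this kind is available, so the size of this change cannot be read from data. The expectation for compound 3 is a step of a 1.1-fold higher number from compound 2 to compound 3 (0.06 log units; within the scatter) that stays within the scatter, with no direction assumed. Compound 3 is estimated at 2500 nM, in the range 800 nM to 8000 nM.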

Compound 3, half-maximal effective concentration: 1350 nM
Compound 3: the middle estimate sits 1.9-fold (0.27 log units) above what was measured; low and high end bracket the measured number.
By their numbers in this assay, from the lowest: compounds 1, 3 and 2 (each within the scatter of the next).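

Exchanging 3-carboxy-4-chlorophenyl for 4-carboxy-3-methylphenyl on an oxygen on a saturated carbon gives, in this assay, a 1.6-fold lower number from compound 2 to compound 3 (0.21 log units; within the scatter). This position therefore accepts a second acid-bearing aryl group, one with methyl rather than chlorine, and this read-out does not tell the two groups apart. Nothing on hand speaks to the reason for this.

Still open, going by these compounds, is whether the acid itself is needed at this position. An aryl group carrying a primary amide or a tetrazole in place of the carboxylic acid would test that.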